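The source may report more compounds than this note shows. Statements on the series, on what has been measured and on what is new or still open speak of the compounds shown alone.

Measured so far in an assay on HEK293 cells for agonist activity at prostaglandin E2 receptor EP2 subtype (Homo sapiens), read by a beta-galactosidase reporter and beta-arrestin recruitment, with a stated time of 90 min; a higher number here means that more compound is needed for the effect, a lower number that less compound is needed:
Compound 1, `O=C(O)c1csc([C@H]2CC[C@@H]3[C@@H](COc4ccc(C(F)(F)F)cc4)[C@H](O)C[C@@H]3O2)n1`, > 10000 nM
Compound 2, `O=C(O)c1csc([C@H]2CC[C@@H]3[C@@H](COc4ccc(OC(F)(F)F)cc4)[C@H](O)C[C@@H]3O2)n1`, 4500 nM
Compound 3, `O=C(O)c1csc([C@H]2CC[C@@H]3[C@@H](/C=C/CCCOc4ccccc4)[C@H](O)C[C@@H]3O2)n1`, > 10000 nM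

Compound 1 gives only a limit in this assay, > 10000 nM, so no number is known for it. The same holds for compound 3, whose value > 10000 nM is also a limit. Going by the values given here, compound 2 is the one measured compound with a number, 4500 nM, and the step of an at least 2.2-fold lower number from compound 1 to compound 2 (0.34 log units; beyond the scatter) shows that trifluoromethoxy in place of trifluoromethyl brought the value into the measurable range. A pattern is hard to read from these three, given (the limit of > 10000 nM in this assay, at which 2 of the 3 values shown sit).

Compound 4, `Cc1ccc(OC[C@@H]2[C@H]3CC[C@H](c4nc(C(=O)O)cs4)O[C@H]3C[C@H]2O)cc1`, differs from compound 1 by methyl in place of trifluoromethyl on an aromatic carbon. Among the compounds with values here, no measured step swaps trifluoromethyl for methyl; the only step touching that position, an at least 2.2-fold lower number from compound 1 to compound 2 (0.34 log units; beyond the scatter), is at least modest and points toward a lower number, but it moves to a different group. For compound 4 the expectation is a value near the limit seen for compound 1, with the step of a number no higher from compound 1 to compound 4 (the limit leaves the size open) estimated as within the scatter. Compound 4 is estimated at 10000 nM, with a range from 3000 nM to 30000 nM.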

Compound 4, half-maximal effective concentration: > 10000 nM
Compound 4 ended at the assay's limit (the forecaster's own chance of this, stated with the estimate: 60%); the middle value lies on the limit itself.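

Compound 4 gives only a limit, > 10000 nM, in this assay, so methyl at this position on the aromatic ring joins trifluoromethyl in giving no number, and the step between compound 1 and compound 4 cannot be read. The comparison of methyl with trifluoromethoxy can be read, and it is an at least 2.2-fold higher number from compound 2 to compound 4 (0.34 log units; beyond the scatter). Among compound 1, compound 2 and compound 4, which differ only in this group, trifluoromethoxy alone gives a number, so a measurable value does not come with every group on this carbon, and the limit still restricts what can be concluded: the limit of > 10000 nM in this assay, at which 3 of the 4 values shown sit.

On these data alone, whether methoxy, chlorine or a nitrile in the same place would also give a number remains open. So does whether any group here could bring the value far lower than that of compound 2, 4500 nM.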